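Amide amine variation at the carbonyl: notes toward compound 4

The source may hold more compounds than are shown below. What is called first, only, known or untested is meant among the compounds shown, and "the series" means these compounds.

Measured so far in a functional assay on L6 cells (Rattus norvegicus) for inhibition; on this read-out higher numbers stand for weaker inhibition and lower numbers for stronger inhibition:
- compound 1, `CCN(Cc1ccccc1)C(=O)c1nn(-c2ccc(F)cc2)c(OC[C@@H](O)C[C@@H](O)CC(=O)O)c1C(C)C`: 2660 nM
- compound 2, `Cc1ccc(CN(C)C(=O)c2nn(-c3ccc(F)cc3)c(OC[C@@H](O)C[C@@H](O)CC(=O)O)c2C(C)C)cc1`: 1250 nM
- compound 3, `CC(C)c1c(C(=O)N2CCCCC2)nn(-c2ccc(F)cc2)c1OC[C@@H](O)C[C@@H](O)CC(=O)O`: 32200 nM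

Compound 3 gives the highest number of the three, and both of its steps to the others are beyond the scatter: a 12-fold higher number from compound 1 to compound 3 (1.08 log units; beyond the scatter) and a 26-fold higher number from compound 2 to compound 3 (1.41 log units; beyond the scatter). The two compounds with an open-chain amine on the carbonyl carbon sit much lower, and between them the difference is only a 2.1-fold lower number from compound 1 to compound 2 (0.33 log units; beyond the scatter), a modest one.

Compound 4, `CC(C)c1c(C(=O)N(C)Cc2cccc(F)c2)nn(-c2ccc(F)cc2)c1OC[C@@H](O)C[C@@H](O)CC(=O)O`, is not yet measured. It differs from compound 3 in one place: (3-fluorobenzyl)(methyl)amino in place of piperidin-1-yl on a carbonyl carbon. The (3-fluorobenzyl)(methyl)amino group that enters is of the same kind as the benzyl(ethyl)amino group of compound 1 and the methyl(4-methylbenzyl)amino group of compound 2, so the steps of a 26-fold higher number from compound 2 to compound 3 (1.41 log units; beyond the scatter) and a 12-fold higher number from compound 1 to compound 3 (1.08 log units; beyond the scatter) bear on this change directly, read in the opposite direction. Both were large. A large step downward in this assay is therefore expected, a 20-fold lower number from compound 3 to compound 4 (1.30 log units; beyond the scatter), placing compound 4 among compounds 1 and 2 rather than near compound 3.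

For compound 4 the estimated value in this assay is 1600 nM, with a range from 600 nM to 4500 nM.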

Compound 4, half-maximal inhibitory concentration: 2470 nM
The estimate for compound 4 lay 1.5-fold (0.19 log units) below the measured number; the range from low to high includes it.
By their numbers in this assay, from the lowest: compounds 2, 4 and 1 (each within the scatter of the next, the first and the last beyond it); then compound 3.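

Replacing piperidin-1-yl on the carbonyl carbon with (3-fluorobenzyl)(methyl)amino gives a 13-fold lower number from compound 3 to compound 4 (1.12 log units; beyond the scatter) in this assay, so a third benzyl-type open-chain amine also separates clearly from the piperidin-1-yl amide of compound 3. Changes on the phenyl ring of that amine count for little in this comparison: with 3-fluorophenyl in place of 4-methylphenyl there is a 2.0-fold higher number from compound 2 to compound 4 (0.30 log units; within the scatter) and, with (3-fluorobenzyl)(methyl)amino in place of benzyl(ethyl)amino, there is a 1.1-fold lower number from compound 1 to compound 4 (0.03 log units; within the scatter) as well. Among the compounds shown, the large gap therefore goes with the piperidin-1-yl group against the three benzyl-type amines, and a 3-fluoro group on the phenyl ring fits the open-chain set as well as the 4-methyl group or the unsubstituted phenyl ring.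

As far as these compounds go, it stays open whether the phenyl ring or the open chain matters here, which an open-chain amine without a ring, such as diethylamino, or a ring amine carrying a benzyl group, such as 4-benzylpiperidin-1-yl, could help to separate. Nothing at hand gives a reason for the gap between compound 3 and the other three compounds.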